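Swapping dimethylamino for azetidin-1-yl: plasma binding outlook

This account rests on a few compounds, and the source may have more. Where it says the series, first, only, none or still open, it means among the compounds named here.

Measured compounds and values:
- compound 1 `CNc1nccc(N2CC[C@H](NC(=O)Nc3ccc(CN(C)C)c(C(F)(F)F)c3)C2)n1`: 94.3%
- compound 2 `O=C(Nc1ccc(Cl)c(C(F)(F)F)c1)N[C@H]1CCN(c2ccnc(NC3CC3)n2)C1`: > 99.9% (a limit)
- compound 3 `CCNc1nccc(N2CC[C@H](NC(=O)Nc3ccc(Cl)c(C(F)(F)F)c3)C2)n1`: > 99.9% (a limit)

All three compounds were tested in an ADME assay on a cell-free system (plasma, Homo sapiens) for protein binding. Among the measured compounds shown here, compound 1 gives 94.3% in this assay, and it is the only compound with a definite number. For compound 2 this assay reports only a limit, > 99.9%. For compound 3 it likewise reports only a limit, > 99.9%. For the measured compounds named here, two of the three values therefore sit at the limit of > 99.9% in this assay, at which 2 of the 3 values shown sit, and the one step between measured compounds, a step that the two limits leave unreadable from compound 2 to compound 3, cannot be sized because both of its ends are limits. As far as these compounds go, the size of that step, which exchanges one small group on a nitrogen of the shared core, is unknown.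

Compound 4 `CNc1nccc(N2CC[C@H](NC(=O)Nc3ccc(CN4CCC4)c(C(F)(F)F)c3)C2)n1` is the next compound to be measured. It differs from compound 1 by azetidin-1-yl in place of dimethylamino on a saturated chain carbon bound to an aromatic carbon. Going by the values given here, none of the measured steps touches this part of the molecule, and the only readable step is itself unreadable, so no measured step bears on this change. With a small group replaced by a slightly larger ring at the same place, the expected step a 1.3-fold lower unbound fraction from compound 1 to compound 4 (0.10 log units; within the scatter) is estimated to lie within the usual scatter. Compound 4 is therefore expected to give about 95.5% in this assay, between 91% and 98.5%.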

Compound 4, plasma protein binding: 86.3%
Compound 4: the middle estimate sits 3.0-fold (0.48 log units) (unbound fraction) below what was measured; measured number outside the range, below it.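

In this assay, among the compounds shown here, this is the first readable change at this position, on a saturated chain carbon bound to an aromatic carbon: a 2.4-fold higher unbound fraction from compound 1 to compound 4 (0.38 log units; beyond the scatter). It shows that exchanging dimethylamino, with 3 heavy atoms and no ring, for azetidin-1-yl, with 4 heavy atoms and one four-membered ring, can move the free share of a compound beyond the usual scatter of repeated measurements, and here the larger group comes with less binding rather than more, although this rests on a single pair of compounds. Nothing measured here accounts for the size or direction of this step, so its cause stays unknown.

As far as these compounds go, the step between compound 2 and compound 3 cannot be read and concerns another part of the molecule, so it offers no comparison for this change: the limit of > 99.9% in this assay, at which 2 of the 4 values shown sit. It also remains open whether the same step would appear with other amines at this position, such as a pyrrolidine or morpholine ring, or on a core carrying the ethyl or cyclopropyl group of those two compounds in place of methyl.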